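The source may report more compounds than this note shows. Statements on the series, on what has been measured and on what is new or still open speak of the compounds shown alone.

Compound 1 `CC(C)c1cc(C(C)(C)C)cc(-c2ccc(F)cc2)c1CO` and compound 2 `CC(C)c1cc(C(C)(C)C)cc(-c2cccc(N(C)C)c2)c1CO` share one core, and compound 3 `CC(C)C(=O)Nc1sc2c(c1C#N)CCCC2` is built on a different one. In a functional assay on RKE cells for antagonist activity at Vasoactive intestinal polypeptide receptor 1 (Rattus norvegicus), read by HTRF and cAMP accumulation, with stated times of 10 min and 30 min (a lower number here means a stronger inhibitor, a higher number a weaker inhibitor), compound 1 gives 740 nM, compound 2 gives 310 nM, and compound 3 gives 3400 nM. Of these three numbers compound 3 has the highest; its nearest neighbour is compound 1, whose number is lower by an amount beyond the scatter, and compound 2 lies further away still, with a lower number also beyond the scatter. Compound 4 `N#Cc1c(NC(=O)c2ccccc2)sc2c1CCCC2` is not yet measured. It differs from compound 3 in one place: phenyl in place of isopropyl on a carbonyl carbon. Within the data shown here, no step between two measured compounds shows what this exchange does, so the expectation rests on compound 3 alone. Compound 4 is expected to give 2500 nM in this assay, within a range from 800 nM to 8000 nM. This expectation means a step of a 1.4-fold lower number from compound 3 to compound 4 (0.13 log units; within the scatter), that is, no change beyond the scatter in either direction.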

Compound 4, half-maximal inhibitory concentration: 15000 nM
Compound 4: middle estimate off by 6.0-fold (0.78 log units), on the low side, and the stated range ends below it.
By their numbers in this assay, from the lowest: compound 2; then compound 1; then compound 3; then compound 4.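

On the carbonyl carbon whose other neighbour is the amide-type nitrogen, the exchange of isopropyl for phenyl gives in this assay a 4.4-fold higher number from compound 3 to compound 4 (0.64 log units; beyond the scatter), so this position is sensitive to the group placed on it. Of the two groups seen there, isopropyl goes with the stronger inhibitor, and phenyl with the weaker one. Nothing in the data shown accounts for this step. Among these compounds, the single step cannot tell whether the loss follows from the ring itself or from the larger count of heavy atoms, and a cyclohexyl group on the same carbonyl carbon would separate the two. As far as these compounds go, how a methyl group, a longer chain or a group carrying an amine would behave at this position remains open, as does any change to the nitrile.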